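The compounds below may be only part of what the source reports. "The series", "measured", "known", "first", "only" and "open" are said of these compounds alone.

Compound 2 `Cc1ccc(CS/C(=C/c2sccc2C)C(=O)c2ccc(Cl)cc2)cc1` and compound 1 `Cc1ccsc1/C=C(/SCc1ccc(Cl)cc1Cl)C(=O)c1ccc(Cl)cc1` share one core. In a functional assay on DU-145 cells (Homo sapiens) for inhibition, read by trypan blue exclusion, with a stated time of 96 h (on this read-out lower numbers stand for stronger inhibition of growth and higher numbers for weaker inhibition of growth), compound 2 gives 10000 nM, and compound 1 gives 10000 nM, which shows no change at the digits printed from compound 1 to compound 2 (within the scatter). Compound 3 `Cc1ccsc1/C=C(/SCc1ccc(F)cc1)C(=O)c1ccc(Cl)cc1` gives 50000 nM in this assay, so there is a 5.0-fold higher number from compound 2 to compound 3 (0.70 log units; beyond the scatter) and a 5.0-fold higher number from compound 1 to compound 3 (0.70 log units; beyond the scatter). Compound 2 thus stands level with compound 1, and the pair together hold the lowest numbers of the three. Compound 4 `Cc1ccc(CS/C(=C/c2ccccc2Br)C(=O)c2ccc(Cl)cc2)cc1` differs from compound 2 elsewhere in the molecule: 2-bromophenyl in place of 3-methylthiophen-2-yl on a double-bonded chain carbon bound to a double-bonded chain carbon. Going by the values given here, none of the measured steps touches that place; each changes only the group on the saturated chain carbon bound to a sulfur. With nothing bearing on it, no change beyond the scatter is expected, and the estimated step is a 1.2-fold higher number from compound 2 to compound 4 (0.08 log units; within the scatter). Compound 4 is therefore expected to give about 12000 nM in this assay, within 3000 nM to 50000 nM.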

Compound 4, concentration for 50% growth inhibition: 10000 nM
For compound 4 the middle estimate is 1.2-fold (0.08 log units) above the measured one, within the range that was stated.
By their numbers in this assay, from the lowest: compounds 1, 2 and 4 (each within the scatter of the next); then compound 3.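

The step at this place reads no change at the digits printed from compound 2 to compound 4 (within the scatter) in this assay, and it is the only step shown on the double-bonded chain carbon. It shows that here a 2-bromophenyl, a six-membered ring of carbon only, can replace a 3-methylthiophen-2-yl, a five-membered ring with a sulfur, with no change beyond the scatter. No evidence is available to explain this result. Going by these compounds, whether an amine or a carboxylic acid at this place would also leave the number unchanged remains open. So does whether this swap would give the same result with 4-fluorophenyl on the saturated chain carbon.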